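Swapping the group on the saturated ring carbon

This account rests on a few compounds, and the source may have more. Where it says the series, first, only, none or still open, it means among the compounds named here.

Measured compounds:
compound 1 `Cc1nn(-c2ncnc3nc[nH]c23)c2c1C(C(=O)Nc1ccccc1)CC(=O)N2` — 10 nM
compound 2 `Cc1nn(-c2ncnc3nc[nH]c23)c2c1C(OCc1ccccc1C#N)CC(=O)N2` — 8 nM

Going by the values given here, in a functional assay on HEK293 cells for agonist activity at G-protein coupled receptor 39 (Homo sapiens), read by scintillation proximity assay and inositol phosphate accumulation, with a stated time of 75 min, in the presence of a further agent that is not named here (a lower number here means that less compound is needed, a higher number that more compound is needed for the effect), compound 2 gives 8 nM, the lowest of the two numbers, yet the only step, a 1.3-fold lower number from compound 1 to compound 2 (0.10 log units; within the scatter), lies within the scatter. Compound 3 `Cc1nn(-c2ncnc3nc[nH]c23)c2c1C(c1ccc(OC(C)C)cc1)CC(=O)N2` has not been measured in this assay. Its change from compound 2 is 4-isopropoxyphenyl in place of (2-cyanobenzyl)oxy on a saturated ring carbon. Among the compounds with values here, the single step at this carbon changed little, so another change at the same place is expected to move the number little, with wider uncertainty because the entering group differs from both earlier ones. Compound 3 is therefore estimated at 15 nM, between 4 nM and 60 nM, a step of a 1.9-fold higher number from compound 2 to compound 3 (0.27 log units; within the scatter) expected to stay near the scatter.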

Compound 3, half-maximal effective concentration: 18 nM
For compound 3 the middle estimate is 1.2-fold (0.08 log units) below the measured one; the measured number falls inside the stated range.
By their numbers in this assay, from the lowest: compounds 2, 1 and 3 (each within the scatter of the next, the first and the last beyond it).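

At the saturated ring carbon, this assay now shows its first step beyond the scatter, a modest one, as a 2.3-fold higher number from compound 2 to compound 3 (0.35 log units; beyond the scatter) when 4-isopropoxyphenyl replaces (2-cyanobenzyl)oxy. Replacing phenylcarbamoyl with the same group gives a 1.8-fold higher number from compound 1 to compound 3 (0.26 log units; within the scatter) and stays within the scatter, so this position accepts three differently built groups with only small differences in the number. No evidence is at hand to explain these steps. The compounds shown leave open whether the nitrile or the benzyl ether oxygen matters on its own. From the compounds shown here alone, how an amine or a carboxylic acid would read at this carbon also remains open.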